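The source may report more compounds than this note shows. Statements on the series, on what has been measured and on what is new or still open speak of the compounds shown alone.

Three compounds share one core and differ only in the group on one aromatic carbon of that core. Compound 1 `COc1ccc(-c2nc(/N=C(\N)N(C)C)sc2-c2ccc(OC)cc2)cc1` carries a dimethylamino group on a carbon with a double bond to nitrogen; in a functional assay with Oryctolagus cuniculus as the target (a higher number here means a weaker inhibitor, a lower number a stronger inhibitor), compound 1 gives 37 nM. Compound 2 `COc1ccc(-c2nc(/N=C(\N)n3ccnc3)sc2-c2ccc(OC)cc2)cc1` carries 1H-imidazol-1-yl in that place. In this assay compound 2 reaches only a limit, > 100 nM. That is a step of an at least 2.7-fold higher number from compound 1 to compound 2 (0.43 log units; beyond the scatter). Compound 3 `CCN(CC)C(=O)c1nc(-c2ccc(OC)cc2)c(-c2ccc(OC)cc2)s1` carries diethylcarbamoyl on the same aromatic carbon. In this assay compound 3 likewise reaches only a limit, < 10 nM. Compound 3 thus sits at the limit of < 10 nM in this assay, at which 1 of the 3 values shown sits, the strong end of what is shown, after steps of an at least 3.7-fold lower number from compound 1 to compound 3 (0.56 log units; beyond the scatter) and an at least 10-fold lower number from compound 2 to compound 3 (1.00 log units; beyond the scatter). Compound 4 `COc1ccc(-c2nc(C3=CCN(C)CC3)sc2-c2ccc(OC)cc2)cc1` is not yet measured; it differs from compound 3 by a group of 7 heavy atoms (6 carbon, 1 nitrogen; one six-membered non-aromatic ring with 1 hetero atom) in place of a group of 7 heavy atoms (5 carbon, 1 nitrogen, 1 oxygen; no ring), on an aromatic carbon. Both measured exchanges at this carbon moved the number beyond the scatter, so a step beyond the scatter is expected for an at least 3.0-fold higher number from compound 3 to compound 4 (0.47 log units; beyond the scatter), toward a higher number, since compound 3 already sits at the limit of < 10 nM in this assay, at which 1 of the 3 values shown sits. Compound 4 is therefore estimated at 30 nM, between 6 nM and 150 nM.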

Compound 4, half-maximal inhibitory concentration: < 10 nM
Compound 4 gave a limit, no number (the forecaster's own chance of this, stated with the estimate: 25%); middle value at least 3.0-fold (0.47 log units) away from the limit.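

Compound 4 sits at the same limit as compound 3, at the strong end of what is shown: the limit of < 10 nM in this assay, at which 2 of the 4 values shown sit. This aromatic carbon therefore takes a group with a six-membered non-aromatic ring and no oxygen, as well as the open-chain diethylcarbamoyl, so the carbonyl of compound 3 is not required to reach that limit. The ring-bearing group also gives an at least 10-fold lower number from compound 2 to compound 4 (1.00 log units; beyond the scatter) and an at least 3.7-fold lower number from compound 1 to compound 4 (0.56 log units; beyond the scatter), so it matches the gain that diethylcarbamoyl showed over the two groups that carry several nitrogens.

As far as these compounds go, the step between compound 3 and compound 4 cannot be read, and which of the two is stronger stays open. Also open, from the compounds shown here alone, is whether a smaller group on this carbon, such as a primary amine or a carboxylic acid, would reach the same limit.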